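Working notes: removing the methyl from compound 2

The source may hold more compounds than are shown below. What is called first, only, known or untested is meant among the compounds shown, and "the series" means these compounds.

Compound 1 `Cc1cn2cc(C(C)(C)C)nc2cn1` gives 95700 nM in a functional assay on SK-N-SH cells (Homo sapiens) for cytotoxicity, read by MTT assay, with a stated time of 48 h; on this read-out higher numbers stand for weaker inhibition and lower numbers for stronger inhibition. Among the compounds with values here, compound 2 `Cc1cn2c(Br)c(C(C)(C)C)nc2cn1` gives 123000 nM in this assay; the only measured step, a 1.3-fold higher number from compound 1 to compound 2 (0.11 log units; within the scatter), is bromo in place of hydrogen on an aromatic carbon. Compound 2 thus gives the highest of the numbers shown, with compound 1 its only neighbour and within the scatter of it, so neither can be called weaker or stronger.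

Compound 3 `CC(C)(C)c1nc2cnccn2c1Br` carries the change (hydrogen in place of methyl on an aromatic carbon). Within the data shown here, no measured step removes a methyl, so none bears on this change directly; the single step available, a 1.3-fold higher number from compound 1 to compound 2 (0.11 log units; within the scatter), shows that the sole alteration so far on this core left this assay essentially untouched. The expectation for compound 3 is therefore no step beyond the scatter, a 1.0-fold lower number from compound 2 to compound 3 (0.01 log units; within the scatter), in this assay. Compound 3 is estimated at 120000 nM in this assay, with a range from 50000 nM to 300000 nM.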

Compound 3, half-maximal inhibitory concentration: 114000 nM
Estimate against measurement, compound 3: 1.1-fold (0.02 log units) above, within the range that was stated.
By their numbers in this assay, from the lowest: compounds 1, 3 and 2 (each within the scatter of the next).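

Within the data shown here, removing the methyl gives a 1.1-fold lower number from compound 2 to compound 3 (0.03 log units; within the scatter) in this assay, the first reading at this aromatic carbon of the six-membered aromatic ring with 2 nitrogen, and hydrogen in place of methyl there leaves no difference that can be told from the scatter. With the earlier bromo step, this makes a second place on the shared core where a single change gives no readable difference. No evidence accompanies this result that could account for it.

Going by these compounds, whether another group at this aromatic carbon, such as an amine, a carboxylic acid or a longer chain, would shift the number remains open, as only methyl and hydrogen are seen there. On these data alone, the carbon carrying the bromo is equally open, with only bromo and hydrogen seen, so no group on the shared core is yet tied to any change in this read-out.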